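Swapping the aryl ketone substituent on a weak cytotoxic series

A few compounds are considered here, and "the series" means these few. Any claim that something is new, unique, unknown or untested is made for them only; others in the source may bear on it.

Measured so far:
compound 1, `COc1cc(-c2nnc3n2NC(c2ccco2)C(C(=O)c2ccccc2C)S3)cc(OC)c1OC`: 69900 nM
compound 2, `COc1cc(-c2nnc3n2NC(c2ccco2)C(C(=O)c2ccc(Br)cc2)S3)cc(OC)c1OC`: > 100000 nM

Among the compounds with values here, compound 1 is the only compound of the set with an actual number in a functional assay on MCF7 cells (Homo sapiens) for cytotoxicity, read by MTT assay, with a stated time of 48 h; a lower number here means a stronger inhibitor, a higher number a weaker inhibitor; compound 1 gives 69900 nM there. As far as these compounds go, for compound 2 the assay reports only a limit, > 100000 nM, so its true value is unknown beyond that, as recorded in the limit of > 100000 nM in this assay, at which 1 of the 2 values shown sits. Within the data shown here, the one measured step, an at least 1.4-fold higher number from compound 1 to compound 2 (0.15 log units; that floor lies within the scatter), therefore cannot be sized precisely.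

Compound 3, `COc1cc(-c2nnc3n2NC(c2ccco2)C(C(=O)c2ccc([N+](=O)[O-])cc2)S3)cc(OC)c1OC`, differs from compound 1 in a single place: 4-nitrophenyl in place of 2-methylphenyl on a carbonyl carbon. Among the measured compounds shown here, the step from compound 1 to compound 2 is the only comparison available and it also exchanges the ring on the carbonyl carbon, so the expectation for compound 3 rests on it alone: a weak compound, likely at or beyond the limit. The expected change is a 1.7-fold higher number from compound 1 to compound 3 (0.23 log units; within the scatter), and compound 3 is estimated at 120000 nM, within 40000 nM to 400000 nM.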

Compound 3, half-maximal inhibitory concentration: > 100000 nM
Compound 3: a limit, no number; the forecaster's own chance of this, stated with the estimate: 60%; the middle value is on the limit's open side.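

Like the 4-bromophenyl of compound 2, the 4-nitrophenyl on the carbonyl carbon yields no actual number: compound 3 is reported only as a limit, > 100000 nM. Exchanging 2-methylphenyl for 4-nitrophenyl gives an at least 1.4-fold higher number from compound 1 to compound 3 (0.15 log units; that floor lies within the scatter), so the data do not firmly separate this pair. A second, different group has now reached the same limit, and the step between compound 2 and compound 3 cannot be read: the limit of > 100000 nM in this assay, at which 2 of the 3 values shown sit.

As far as these compounds go, what a plain phenyl ring, or a ring carrying a methoxy group or an amine, would do on this carbonyl carbon remains open. Within the data shown here, with compound 1 the only one giving a number, how far compound 2 and compound 3 actually lie from it is also unknown.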